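Trifluoromethyl for Chloro: Stability of a Fourth Compound

A few compounds are considered here, and "the series" means these few. Any claim that something is new, unique, unknown or untested is made for them only; others in the source may bear on it.

Compound 1, `CC(=O)N1CCN(c2cc(-c3cc(Cl)c4c(N)ncnn34)ccc2C(F)(F)F)C(=O)C1(C)C`: 88%
Compound 2, `CC(=O)N1CCN(c2cc(-c3cc(C(F)(F)F)c4c(N)ncnn34)ccc2C(F)(F)F)C(=O)C1(C)C`: 99%
Compound 3, `CC(=O)N1C[C@@H](C)N(c2cc(-c3cc(Cl)c4c(N)ncnn34)ccc2C#N)C(=O)C1(C)C`: 22%

In an ADME assay on microsomes from liver (Mus musculus) for metabolic stability, read by LC-MS, using NADPH, with stated times of 6 min and 10 min, tested at 0.5 uM (on this read-out lower numbers stand for a less stable compound and higher numbers for a more stable compound), compound 1 gives 88%, and compound 2, which differs from it by trifluoromethyl in place of chloro on an aromatic carbon, gives 99%; this change made a number 11 percentage points higher from compound 1 to compound 2 (beyond the scatter). Compound 3 gives 22% in this assay, the lowest number of the three; how its core differs from that of compound 1 is not broken down here. Compound 4, `CC(=O)N1C[C@@H](C)N(c2cc(-c3cc(C(F)(F)F)c4c(N)ncnn34)ccc2C#N)C(=O)C1(C)C`, is not yet measured and differs from compound 3 by trifluoromethyl in place of chloro on an aromatic carbon, the same change at the same place as from compound 1 to compound 2. Since that earlier change made a number 11 percentage points higher from compound 1 to compound 2 (beyond the scatter), a step of similar size is expected here, a number 11 percentage points higher from compound 3 to compound 4 (beyond the scatter), though from a much lower starting point. Compound 4 is therefore estimated at 33%, likely between 15% and 60%.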

Compound 4, percent of the compound remaining: 23%
Estimate against measurement, compound 4: 10 percentage points above; low and high end bracket the measured number.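

In this assay, putting trifluoromethyl in place of chloro on an aromatic carbon gives a number 1 percentage points higher from compound 3 to compound 4 (within the scatter). Set beside the earlier step, the two results cannot be told apart: the same change on two cores in this assay, a number 11 percentage points higher (beyond the scatter) from compound 1 to compound 2 and a number 1 percentage points higher (within the scatter) from compound 3 to compound 4, 10 percentage points apart, within the scatter of two such steps. For the compounds shown here, this shows no sign that the change behaves differently on the two cores, but it does not prove that the step carries over, as there are only two pairs and just one of the steps lies beyond the scatter.

From the compounds shown here alone, it remains open how the change would behave on further cores, and which of the differences between the cores of compound 1 and compound 3 goes with the much lower numbers. Also open, going by these compounds, is what an amine or a methoxy group would give in the place of chloro.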